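A few compounds are considered here, and "the series" means these few. Any claim that something is new, unique, unknown or untested is made for them only; others in the source may bear on it.

Working notes on the series. The shared core is seen in compound 1 `FC(F)(F)c1ccnc(Nc2cccc(-c3ccnc(N4CCNCC4)c3)n2)c1`, which in an ADME assay on CHO cells (Cricetulus griseus) for cytotoxicity (on this read-out higher numbers stand for weaker inhibition and lower numbers for stronger inhibition), gives 1000 nM. Compound 2 `O=C(Cc1cccnc1)Nc1cc(Nc2cnccn2)nc(-c2ccnc(N3CCNCC3)c2)c1` and compound 3 `O=C(Nc1cc(Nc2cnccn2)nc(-c2ccnc(N3CCNCC3)c2)c1)c1cncnc1` carry an added amide on that core. In this assay compound 2 gives only a limit, > 20000 nM. Compound 3 also gives only a limit, > 20000 nM. Among the measured compounds shown here, the one measured step, a step that the two limits leave unreadable from compound 2 to compound 3, is therefore of unreadable size, as both of its values sit at the limit of > 20000 nM in this assay, at which 2 of the 3 values shown sit. On the numbers shown compound 3 stands at the weak end of the series, without a number of its own.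

Compound 4 `Oc1ccc(CNc2cc(Nc3cnccn3)nc(-c3ccnc(N4CCNCC4)c3)c2)cc1` differs from compound 3 by 4-hydroxybenzyl in place of (pyrimidin-5-yl)carbonyl on a nitrogen on an aromatic ring. For the measured compounds named here, no measured step bears directly on this change: the only step on record alters the group on the carbonyl carbon and cannot be read, and compound 1 differs from compound 3 in more than one place. Compound 4 is expected to remain in the same weak region, at an estimated 15000 nM with a range from 4000 nM to 40000 nM. This amounts to an expected step of an at least 1.3-fold lower number from compound 3 to compound 4 (0.12 log units; that floor lies within the scatter), with a fair chance that only a limit is returned.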

Compound 4, half-maximal inhibitory concentration: > 20000 nM
Compound 4 ended at the assay's limit; the forecaster's own chance of this, stated with the estimate: 55%; middle value at least 1.3-fold (0.12 log units) from the limit.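

In this assay compound 4 returns only a limit, > 20000 nM. The steps to compound 4 from compound 2 and compound 3 cannot be read, as all three values sit at the same limit: the limit of > 20000 nM in this assay, at which 3 of the 4 values shown sit.

The compounds shown leave open whether 4-hydroxybenzyl in place of (pyrimidin-5-yl)carbonyl changes the read-out at all.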